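The compounds below may be only part of what the source reports. "The series", "measured", "known", "first", "only" and "open" are said of these compounds alone.

In a functional assay for agonist activity at 5-hydroxytryptamine receptor 4 (Homo sapiens), read by cAMP accumulation (on this read-out higher numbers stand for an effect only at larger amounts of compound and lower numbers for an effect already at smaller amounts), compound 2 `CCc1nc2c(C(=O)NCC3CCN(CC(O)CN4CCN(S(C)(=O)=O)CC4)CC3)cccc2[nH]1` gives 1 nM, the lowest number among the three measured compounds. Compound 1 `CC(=O)N1CCN(CCN2CCC(CNC(=O)c3cccc4[nH]c(C(C)C)nc34)CC2)CC1` gives 3.16 nM, and compound 3 `CS(=O)(=O)N1CCN(CC(O)CN2CCC(NC(=O)c3cccc4[nH]cnc34)CC2)CC1` gives 631 nM; both numbers are higher than that of compound 2 by more than the usual scatter, so compound 2 is the most potent of the three. The unmeasured compound 4 `CS(=O)(=O)N1CCN(CC(O)CN2CCC(CNC(=O)c3cccc4[nH]c(C5CC5)nc34)CC2)CC1` differs from compound 2 in one place: cyclopropyl in place of ethyl on an aromatic carbon. Among the measured compounds shown here, no measured pair shows this exact change. Compound 1, which carries a different small group at the same place, gives 3.16 nM, not far from compound 2, so the exchange is expected to move the number little, if at all beyond the scatter. Compound 4 is expected to give 1.5 nM, within a range from 0.5 nM to 5 nM. This corresponds to an expected step of a 1.5-fold higher number from compound 2 to compound 4 (0.18 log units; within the scatter).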

Compound 4, half-maximal effective concentration: 0.631 nM
Compound 4: middle estimate off by 2.4-fold (0.38 log units), on the high side; the range from low to high includes it.
By their numbers in this assay, from the lowest: compounds 4 and 2 (each within the scatter of the next); then compound 1; then compound 3.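

In this assay the exchange of ethyl for cyclopropyl on this aromatic carbon, between two ring nitrogen atoms, gives a 1.6-fold lower number from compound 2 to compound 4 (0.20 log units; within the scatter) and so does not separate the two compounds. This place therefore accepts a three-membered ring of carbon as well as an open ethyl group, and the number stays very low. Nothing at hand explains why the two groups read alike. Still open, going by these compounds, is how this place responds to a larger ring such as phenyl, a longer chain such as butyl, or an amine.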